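The source may hold more compounds than are shown below. What is called first, only, known or untested is meant among the compounds shown, and "the series" means these compounds.

Compound 1 `OC1CCC(Nc2nc(-c3ccccc3)nc3c2nnn3Cc2ccccc2F)CC1` is measured in an assay on isolated protein for binding affinity to adenosine receptor A1 (Bos taurus) (a lower number here means a stronger inhibitor, a higher number a weaker inhibitor), and gives 1850000 nM, the lowest of three numbers. Compound 2 `Fc1ccccc1Cn1nnc2c(NC3CC3)nc(-c3ccccc3)nc21` gives 15000000 nM, and compound 3 `CC(O)CNc1nc(-c2ccccc2)nc2c1nnn2Cc1ccccc1F` gives 4800000 nM. The measured steps all alter the group on the ring nitrogen: an 8.1-fold higher number from compound 1 to compound 2 (0.91 log units; beyond the scatter), a 2.6-fold higher number from compound 1 to compound 3 (0.41 log units; beyond the scatter) and a 3.1-fold lower number from compound 2 to compound 3 (0.49 log units; beyond the scatter). Compound 4 `OC1CCC(Nc2nc(-c3ccccc3)nc3c2nnn3Cc2ccccc2Cl)CC1` differs from compound 1 elsewhere: chloro in place of fluoro on an aromatic carbon. Going by the values given here, no measured step touches that halogen, so none bears directly on this change. Swapping one halogen for another of similar size is usually a small move, so for compound 4 the expected step is no change at the digits printed from compound 1 to compound 4 (within the scatter), within the scatter. Compound 4 is therefore estimated at 1850000 nM in this assay, in a range from 600000 nM to 5500000 nM.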

Compound 4, inhibition constant: 3100000 nM
Compound 4: middle estimate off by 1.7-fold (0.22 log units), on the low side, within the range that was stated.
By their numbers in this assay, from the lowest: compounds 1, 4 and 3 (each within the scatter of the next, the first and the last beyond it); then compound 2.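

Going by these compounds alone, the step of a 1.7-fold higher number from compound 1 to compound 4 (0.22 log units; within the scatter) in this assay is the first reading away from the group on the ring nitrogen. On this aromatic carbon, ortho to a large group, chloro and fluoro cannot be told apart, whereas each listed change on that nitrogen moved the number beyond the scatter. No measured evidence bears on this result.

As far as these compounds go, whether methyl or methoxy at this position would also leave the number within the scatter stays open. So does whether chloro behaves the same way with cyclopropyl or 2-hydroxypropyl on the ring nitrogen.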